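Swapping trifluoromethyl for methyl on compound 3

The source may report more compounds than this note shows. Statements on the series, on what has been measured and on what is new or still open speak of the compounds shown alone.

Measured in a functional assay on the whole organism for inhibition, with Rattus norvegicus as the target; a lower number here means that less compound is needed, a higher number that more compound is needed for the effect:
compound 1 `CC(C)c1ccc(OC(Cc2ccc(C(F)(F)F)cc2)C(=O)O)cc1` gives 10 mg/kg
compound 2 `Cc1ccc(CC(Oc2ccc(C(C)C)cc2)C(=O)O)cc1` gives < 50 mg/kg
compound 3 `CC(C)c1ccc(OC(C)(Cc2ccc(C(F)(F)F)cc2)C(=O)O)cc1` gives < 5 mg/kg

Compound 3 stands at < 5 mg/kg and that value is a limit. Compound 2 also has a limit, < 50 mg/kg, and not a number. Compound 4 `Cc1ccc(CC(C)(Oc2ccc(C(C)C)cc2)C(=O)O)cc1` has methyl in place of trifluoromethyl on an aromatic carbon, para to a large group: methyl in place of trifluoromethyl on an aromatic carbon. The same swap on compound 1 gave a step that the limit leaves unreadable from compound 1 to compound 2, so it offers no size. Compound 4 keeps the methyl behind an at least 2.0-fold lower number from compound 1 to compound 3 (0.30 log units; that floor lies within the scatter), which points to a low number. A modest move to a higher number is expected, and the estimated step is an at least 1.2-fold higher number from compound 3 to compound 4 (0.07 log units; that floor lies within the scatter). In this assay compound 4 is estimated at 6 mg/kg, within 1.5 mg/kg to 30 mg/kg.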

Compound 4, dose for half-maximal effect: < 1 mg/kg
Compound 4 ended at the assay's limit; the forecaster's own chance of this, stated with the estimate: 45%; at least 6.0-fold (0.77 log units) between middle value and limit.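

In this assay compound 4 gives < 1 mg/kg, which is a limit. Compound 2 and compound 3 also carry limits, so neither step to compound 4 can be read. The compounds shown leave open how far the dose moves when methyl replaces trifluoromethyl.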